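This account rests on a few compounds, and the source may have more. Where it says the series, first, only, none or still open, it means among the compounds named here.

Three measured compounds share a core and differ at two places. Compound 2 `COc1ccc(F)cc1CNCCCNc1ccnc2cc(Cc3cc(C)cc(C)c3)ccc12` gives 9.47 in a physicochemical assay for acid dissociation. Compound 1 `COc1cccc(CNCCCNc2ccnc3cc(Cc4cc(C)cc(C)c4)ccc23)c1O` gives 9.47 in this assay, and the step of no change at the digits printed from compound 2 to compound 1 (within the scatter) belongs to the change (2-hydroxy-3-methoxyphenyl in place of 5-fluoro-2-methoxyphenyl on a saturated chain carbon bound to an amine nitrogen). Compound 3 `COc1ccc(F)cc1CNCCCNc1ccnc2cc(CCc3ccccc3)ccc12` gives 9.47 in this assay; its core differs from that of compound 2 by benzyl in place of 3,5-dimethylphenyl on a saturated chain carbon bound to an aromatic carbon, and the step of no change at the digits printed from compound 2 to compound 3 (within the scatter) shows that this core change leaves the acid dissociation constant where it was, within the scatter. Compound 4 `COc1cccc(CNCCCNc2ccnc3cc(CCc4ccccc4)ccc23)c1O` is not yet measured. It differs from compound 3 by 2-hydroxy-3-methoxyphenyl in place of 5-fluoro-2-methoxyphenyl on a saturated chain carbon bound to an amine nitrogen, the same change that was made from compound 2 to compound 1, and at the same place. Since compound 1 and compound 2 already show no change at the digits printed from compound 2 to compound 1 (within the scatter), and compound 3 sits level with both, a step of the same small size is expected from compound 3 to compound 4, namely no change at the digits printed from compound 3 to compound 4 (within the scatter). Compound 4 is therefore estimated to give 9.47 in this assay, expected to lie between 9.2 and 9.75.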

Compound 4, acid dissociation constant: 9.47
Compound 4: middle estimate and measured number agree at the digits printed; the range from low to high includes it.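

In this assay, placing 2-hydroxy-3-methoxyphenyl in place of 5-fluoro-2-methoxyphenyl on a saturated chain carbon bound to an amine nitrogen gives no change at the digits printed from compound 3 to compound 4 (within the scatter), the same outcome as on the other core, where the step is no change at the digits printed from compound 2 to compound 1 (within the scatter). The core change also reads the same with either group in place, with no change at the digits printed from compound 1 to compound 4 (within the scatter) alongside no change at the digits printed from compound 2 to compound 3 (within the scatter), so across these four compounds the two changes combine without any step beyond the scatter. Within the data shown here, this shows only that a change with no visible step on one core also has none on the other; it does not show how a step of real size would carry over, and nothing available bears on why the value holds.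

The compounds shown leave open whether the read-out would stay level with a carboxylic acid or a dimethylamino group in place of 2-hydroxy-3-methoxyphenyl. They also leave open what a longer chain in the shared core would do.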